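This account rests on a few compounds, and the source may have more. Where it says the series, first, only, none or still open, it means among the compounds named here.

Measured compounds:
- compound 1, `COc1cccc(COc2ccc3cc(C(=O)/C=C/c4cccc(OC)c4OC)c(=O)oc3c2)c1`: 22800 nM
- compound 2, `COc1cccc(COc2ccc3cc(C(=O)/C=C/c4ccc(Cl)cc4Cl)c(=O)oc3c2)c1`: "not determined" (no result reported)
- compound 3, `COc1cccc(/C=C/C(=O)c2cc3cc(OCc4ccccc4)ccc3oc2=O)c1OC`: 23600 nM

This account follows the step from compound 2 to compound 4. In a functional assay on MOLT-4 cells (Homo sapiens) for cytotoxicity, read by MTT assay, with a stated time of 72 h (on this read-out lower numbers stand for stronger inhibition and higher numbers for weaker inhibition), compound 1 gives 22800 nM, and compound 3 gives 23600 nM; the two numbers lie within the usual scatter of each other, so neither compound can be called stronger than the other. Compound 2 stands apart: in this assay it has no number at all, since no result was reported for it, so it offers no anchor of its own.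

Compound 4, `COc1cccc(COc2ccc3cc(C(=O)/C=C/c4ccccc4)c(=O)oc3c2)c1`, differs from compound 2 in one place: phenyl in place of 2,4-dichlorophenyl on a double-bonded chain carbon bound to a double-bonded chain carbon. Within the data shown here, no measured pair in this set shares that change, so its size cannot be read from the data. Among the measured compounds shown here, the only guide is that compound 1 and compound 3, both carrying the shared core with a substituted aryl on the chain, sit close together in this assay. For the measured compounds named here, compound 4 is therefore expected to land in that same weak region, with no step of a size beyond the scatter foreseen in either direction relative to those two. The estimate for compound 4 in this assay is 25000 nM, within a range from 8000 nM to 80000 nM.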

Compound 4, half-maximal inhibitory concentration: > 100000 nM
Compound 4 gave a limit, no number; the forecaster's own chance of this, stated with the estimate: 20%; at least 4.0-fold (0.60 log units) between middle value and limit.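

In this assay compound 4 gives > 100000 nM, which is a limit and not a number: the limit of > 100000 nM in this assay, at which 1 of the 4 values shown sits.

Phenyl in place of 2,3-dimethoxyphenyl on a double-bonded chain carbon bound to a double-bonded chain carbon goes with an at least 4.3-fold higher number from compound 1 to compound 4 (0.64 log units; beyond the scatter), so in this one pair the change at this position moves the read-out beyond the scatter. Among these compounds, compound 1 and compound 3 both carry 2,3-dimethoxyphenyl at this place, so they could not show that what the aryl ring carries matters here, and the comparison with the unsubstituted phenyl of compound 4 is the first sign that it does.

From the compounds shown here alone, compound 2 has no result in this assay, so the step from 2,4-dichlorophenyl to phenyl cannot be read, and it stays unknown whether the two chlorines would hold the read-out as the two methoxy groups do. Also open, going by these compounds, are how far past its limit compound 4 lies and whether a single methoxy group, a hydroxy group or an amine on this phenyl ring would keep the read-out of compound 1 or lose it.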